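Working notes: fluoro in place of methyl, compound 4

The source may report more compounds than this note shows. Statements on the series, on what has been measured and on what is new or still open speak of the compounds shown alone.

Measured so far in a functional assay on HCT-116 cells (Homo sapiens) for inhibition, read by CCK-8 assay, with a stated time of 72 h, tested at 2 uM; a higher number here means more inhibition of growth at the concentration tested, a lower number less inhibition of growth

compound 1 `Cc1cc(C)cc(SCc2ccc(/C=C/C(=O)Nc3ccccc3N)cc2)c1` gives 7.98%
compound 2 `Nc1ccccc1NC(=O)/C=C/c1ccc(CSc2ccc(Cl)cc2)cc1` gives 5.62%
compound 3 `Cc1ccc(SCc2ccc(/C=C/C(=O)Nc3ccccc3N)cc2)cc1` gives 6.23%

Compound 3 (6.23%) stands within the scatter of both compound 1 and compound 2, so the three values cannot be ranked. The next compound to be measured is compound 4 `Nc1ccccc1NC(=O)/C=C/c1ccc(CSc2ccc(F)cc2)cc1`, which has fluoro in place of methyl on an aromatic carbon, para to a large group fluoro in place of methyl on an aromatic carbon and is otherwise unchanged.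

Closest in kind is methyl in place of chloro on an aromatic carbon, which gave a number 0.6 percentage points higher from compound 2 to compound 3 (within the scatter) in this assay and shows no measurable step. The two replacements of the 3,5-dimethylphenyl group on sulfur gave a number 2.4 percentage points lower from compound 1 to compound 2 (within the scatter) and a number 1.8 percentage points lower from compound 1 to compound 3 (within the scatter) in the same test. None of these three steps leaves the scatter, and no direction can be read from them. Fluoro has not yet been tested in this series, so some uncertainty remains.

The expected a number 0.2 percentage points lower from compound 3 to compound 4 (within the scatter) is therefore no step beyond the scatter. For compound 4 the estimated value is 6% (expected range 1% to 13%).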

Compound 4, percent growth inhibition at one concentration: 14.1%
Compound 4: middle estimate off by 8.1 percentage points, on the low side; measured number outside the range, above it.
By their numbers in this assay, from the lowest: compounds 2, 3, 1 and 4 (each within the scatter of the next).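

In this assay, at the aromatic carbon para to a large group, fluoro in place of methyl gives a number 7.9 percentage points higher from compound 3 to compound 4 (within the scatter) and fluoro in place of chloro gives a number 8.5 percentage points higher from compound 2 to compound 4 (within the scatter) in this series. Measured against the 3,5-dimethylphenyl group on sulfur, the 4-fluorophenyl group gives a number 6.1 percentage points higher from compound 1 to compound 4 (within the scatter) at the same read-out. These steps are larger than the earlier ones among compound 1, compound 2 and compound 3, yet all three remain within the scatter, so fluoro cannot be ranked against methyl, chloro or the 3,5-dimethylphenyl group.

No supporting data bear on the size of these steps.
On these data alone, whether a methoxy group or an amine on this same aromatic carbon would give a step beyond the scatter remains open.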